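Replacing One Halogenated Aryl Group with Another

This account rests on a few compounds, and the source may have more. Where it says the series, first, only, none or still open, it means among the compounds named here.

Measured compounds:
compound 1 `COc1cc(O)c(C(=O)/C=C/c2ccc(OCc3cn(-c4ccc(F)cc4Cl)nn3)c(OC)c2)c(OC)c1`: > 100 ug/mL
compound 2 `COc1cc(OC)c2c(=O)cc(-c3ccc(OCc4cn(-c5ccc(F)c(Cl)c5)nn4)c(OC)c3)oc2c1`: > 100 ug/mL

In an ADME assay on Huh-7 cells (Homo sapiens) for cytotoxicity, read by MTT assay, with a stated time of 72 h (on this read-out higher numbers stand for lower toxicity in this test and lower numbers for higher toxicity in this test), compound 1 gives > 100 ug/mL, which is a limit of the assay rather than a number. Compound 2, with a different core, also reaches > 100 ug/mL in this assay, again only a limit. Among the measured compounds shown here, compound 1 therefore stands where every value shown stands: at the limit of > 100 ug/mL in this assay, at which 2 of the 2 values shown sit, so no order between the two compounds can be drawn, and no measured step connects them.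

Compound 3 `COc1cc(O)c(C(=O)/C=C/c2ccc(OCc3cn(-c4ccc(Cl)cc4)nn3)c(OC)c2)c(OC)c1` differs from compound 1 in one place, (4-chlorophenyl in place of 2-chloro-4-fluorophenyl on an aromatic nitrogen), that is, 4-chlorophenyl in place of 2-chloro-4-fluorophenyl on an aromatic nitrogen. For the measured compounds named here, with no measured step to lean on, the change from compound 1 to compound 3 is expected to stay within the scatter of this assay, as a step that the limit leaves unreadable from compound 1 to compound 3 expresses. Compound 3 is accordingly expected to give about 120 ug/mL in this assay, within 50 ug/mL to 300 ug/mL, most likely again only as a limit.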

Compound 3, half-maximal cytotoxic concentration: > 100 ug/mL
Compound 3 was reported as a limit (the forecaster's own chance of this, stated with the estimate: 75%); the middle value lies beyond the limit too.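

In this assay, compound 3 and compound 1 both stand at a limit rather than a number, so no step can be read between them: the limit of > 100 ug/mL in this assay, at which 3 of the 3 values shown sit.

The compounds shown leave open whether 4-chlorophenyl and 2-chloro-4-fluorophenyl differ at all in this assay.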